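Diethylamino for dimethylamino on two closely related cores

The source may report more compounds than this note shows. Statements on the series, on what has been measured and on what is new or still open speak of the compounds shown alone.

Measured compounds:
compound 1, `CN(C)CCCCn1c(N)c(-c2nc3ccccc3o2)c2nc(C#N)c(C#N)nc21`, gives 640 nM
compound 2, `CCN(CC)CCCCn1c(N)c(-c2nc3ccccc3o2)c2nc(C#N)c(C#N)nc21`, gives 450 nM
compound 3, `CN(C)CCCCn1c(N)c(-c2nc3ccccc3n2C)c2nc(C#N)c(C#N)nc21`, gives 740 nM

All three were tested in a functional assay on HL-60 cells (Homo sapiens) for antiproliferative activity, read by MTT assay, with a stated time of 48 h; on this read-out higher numbers stand for weaker inhibition and lower numbers for stronger inhibition. Compound 1 and compound 2 share one core and differ by diethylamino in place of dimethylamino on a saturated chain carbon, four bonds along the chain from an aromatic nitrogen; this change produced a 1.4-fold lower number from compound 1 to compound 2 (0.15 log units; within the scatter). Compound 3 carries a second core, which differs from that of compound 1 by 1-methyl-1H-benzimidazol-2-yl in place of 1,3-benzoxazol-2-yl on an aromatic carbon, and in this assay the two cores read a 1.2-fold higher number from compound 1 to compound 3 (0.06 log units; within the scatter). The three numbers therefore sit close together and no ordering among them can be claimed.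

Compound 4, `CCN(CC)CCCCn1c(N)c(-c2nc3ccccc3n2C)c2nc(C#N)c(C#N)nc21`, has not been measured. It differs from compound 3 by diethylamino in place of dimethylamino on a saturated chain carbon, four bonds along the chain from an aromatic nitrogen, the same change that separates compound 2 from compound 1, made at the same place. On that pairing, compound 4 is expected to show a 1.4-fold lower number from compound 3 to compound 4 (0.14 log units; within the scatter) in this assay, set beside a 1.4-fold lower number from compound 1 to compound 2 (0.15 log units; within the scatter), and the expectation rests only on that single earlier step. The estimate for compound 4 is 530 nM, with a likely range from 250 nM to 1100 nM.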

Compound 4, half-maximal inhibitory concentration: 700 nM
Estimate against measurement, compound 4: 1.3-fold (0.12 log units) below; the range from low to high includes it.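

In this assay, diethylamino in place of dimethylamino on the core of compound 3 gives a 1.1-fold lower number from compound 3 to compound 4 (0.02 log units; within the scatter) and so reads the same as the earlier step on the core of compound 1: the same change on two cores in this assay, a 1.4-fold lower number (0.15 log units; within the scatter) from compound 1 to compound 2 and a 1.1-fold lower number (0.02 log units; within the scatter) from compound 3 to compound 4, 1.3-fold (0.13 log units) apart, within the scatter of two such steps.
The swap of 1,3-benzoxazol-2-yl for 1-methyl-1H-benzimidazol-2-yl, read this time on the diethylamino pair, gives a 1.6-fold higher number from compound 2 to compound 4 (0.19 log units; within the scatter) and agrees in the same way with its earlier reading: the same change on two cores in this assay, a 1.2-fold higher number (0.06 log units; within the scatter) from compound 1 to compound 3 and a 1.6-fold higher number (0.19 log units; within the scatter) from compound 2 to compound 4, 1.3-fold (0.13 log units) apart, within the scatter of two such steps.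
This shows that on these two cores the change from dimethylamino to diethylamino left the number within the scatter both times, so the two steps cannot be told apart; it does not show that the change has a real effect of its own, nor that the agreement would hold on any further core.

As far as these compounds go, what a longer chain would do at this place remains open. So does the outcome with a primary amine or a carboxylic acid in place of the diethylamino group.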